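Changing the group on the oxygen of compound 1

A few compounds are considered here, and "the series" means these few. Any claim that something is new, unique, unknown or untested is made for them only; others in the source may bear on it.

Three compounds carry numbers in an ADME assay on a cell-free system (plasma, Rattus norvegicus, strain Sprague-Dawley) for metabolic stability, read by LC-MS (on this read-out lower numbers stand for a shorter-lived compound and higher numbers for a longer-lived compound), so far, and all three hold the same group on the oxygen. Compound 1 (`COc1ccc2c(c1)c(CC(=O)OCCOc1ccc3oc(=O)ccc3c1)c(C)n2C(=O)c1ccc(Cl)cc1`) gives 0.0467 h here. Compound 2 (`CC(C(=O)OCCOc1ccc2oc(=O)ccc2c1)c1cccc(C(=O)c2ccccc2)c1`) gives 0.0783 h and lies within the scatter of compound 1. Compound 3 (`COc1ccc2cc([C@H](C)C(=O)OCCOc3ccc4oc(=O)ccc4c3)ccc2c1`) gives 0.0183 h and lies lower than compound 1 by more than the scatter. Among the measured compounds shown here, no measured pair differs in one place, so the data hold no direct evidence on the change to be tested.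

Compound 4 (`COc1ccc2c(c1)c(CC(=O)OCCOc1ccc3ccc(=O)oc3c1)c(C)n2C(=O)c1ccc(Cl)cc1`) has the same atoms as compound 1, joined differently: a group of 11 heavy atoms (9 carbon, 2 oxygen; one six-membered aromatic ring of carbon only, one six-membered aromatic ring with 1 hetero atom) in place of a group of 11 heavy atoms (9 carbon, 2 oxygen; one six-membered aromatic ring of carbon only, one six-membered aromatic ring with 1 hetero atom), on an oxygen on a saturated carbon is the whole difference. Without a measured precedent, no step beyond the scatter is expected in this assay for this change. The expectation is anchored on compound 1 at 0.0467 h alone. The expected step is a 1.1-fold higher number from compound 1 to compound 4 (0.03 log units; within the scatter) and it stays within the scatter. For compound 4 the estimate is 0.05 h with an expected range from 0.02 h to 0.12 h in this read-out.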

Compound 4, half-life: 0.0333 h
Beside the measured number, compound 4's estimate is 1.5-fold (0.18 log units) above it; the range from low to high includes it.
By their numbers in this assay, from the lowest: compounds 3, 4, 1 and 2 (each within the scatter of the next, the first and the last beyond it).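

Among the compounds shown here, the first direct reading at this position in this assay is a 1.4-fold lower number from compound 1 to compound 4 (0.15 log units; within the scatter) and it stays within the scatter. For the compounds shown here, on the core of compound 1, two groups with the same atoms, joined differently, on an oxygen on a saturated carbon therefore cannot be told apart in this read-out, which the earlier compounds could not show. Nothing on hand accounts for the step.

On these data alone, it remains open whether a group of a different make-up on this oxygen, such as a plain phenyl or a simple methyl in place of the two-ring group, would move the number beyond the scatter. As far as these compounds go, it also remains open whether the same exchange would stay within the scatter on the parts of compound 2 and compound 3 that differ from compound 1.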